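A few compounds are considered here, and "the series" means these few. Any claim that something is new, unique, unknown or untested is made for them only; others in the source may bear on it.

Measured compounds:
compound 1 `COc1cccc(N2CCN(C(=O)CN3C(=O)CC(C)(c4ccccc4)C3=O)CC2)c1` in a functional assay on the whole organism (strain CD-1) with Mus musculus as the target, with a stated time of 2 h; on this read-out lower numbers stand for an effect already at smaller amounts and higher numbers for an effect only at larger amounts of compound: "not active" (no number reported)
compound 2 `CC1(c2ccccc2)CC(=O)N(CC(=O)N2CCN(c3ccccc3)CC2)C1=O`: 300 mg/kg
compound 3 `CC1(c2ccccc2)CC(=O)N(CC(=O)N2CCN(c3ccccc3Cl)CC2)C1=O`: 100 mg/kg

Compound 3 stands lowest of the two numbers reported; the nearest is compound 2, reached by a 3.0-fold lower number from compound 2 to compound 3 (0.48 log units; beyond the scatter). Compound 1 gave no number. Compound 4 `CC1(c2ccccc2)CC(=O)N(CC(=O)N2CCN(c3ncccn3)CC2)C1=O` differs from compound 3 by pyrimidin-2-yl in place of 2-chlorophenyl on an amine nitrogen in a ring. Going by the values given here, no measured step bears on this change: the only step, a 3.0-fold lower number from compound 2 to compound 3 (0.48 log units; beyond the scatter), concerns chloro on an aromatic carbon, not a heteroaromatic ring in place of the whole aryl group. The chloro is lost here, so the expectation is a modest rise in the number, about a 3.0-fold higher number from compound 3 to compound 4 (0.48 log units; beyond the scatter), with wide uncertainty. Compound 4 is therefore estimated at 300 mg/kg, within 100 mg/kg to 1000 mg/kg.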

Compound 4, minimum effective dose: 100 mg/kg
For compound 4 the middle estimate is 3.0-fold (0.48 log units) above the measured one, within the range that was stated.
By their numbers in this assay, from the lowest: compounds 3 and 4 (each within the scatter of the next); then compound 2.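

In this assay, the group on the amine nitrogen in a ring need not be a carbon-only aromatic ring: pyrimidin-2-yl in place of 2-chlorophenyl gives (no change at the digits printed from compound 3 to compound 4 (within the scatter)). Pyrimidin-2-yl in place of phenyl gives (a 3.0-fold lower number from compound 2 to compound 4 (0.48 log units; beyond the scatter)), so a lower number than that of compound 2 is also reached without chloro. No available evidence bears on the reason for this result.

Open, as far as these compounds go, is how an amino group or a nitrile on the pyrimidin-2-yl ring would read here. Also open, from the compounds shown here alone, is how pyridin-2-yl would read in the same place.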